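Azole swap at the aryl terminus of the series

The source may hold more compounds than are shown below. What is called first, only, known or untested is meant among the compounds shown, and "the series" means these compounds.

Measured so far in a functional assay on HEK293 cells for agonist activity at Bombesin receptor subtype-3 (Homo sapiens), read by luminescence and calcium flux, with a stated time of 10 min; a higher number here means that more compound is needed for the effect, a lower number that less compound is needed:
Compound 1 `CCC(C)(C)Cc1c[nH]c(CCc2ccc(-c3cccc(C)n3)cc2)n1` gives 102 nM.
Compound 2 `CCC(C)(C)Cc1c[nH]c(CCc2ccc(-n3cccn3)cc2)n1` gives 106 nM.

Among the compounds with values here, compound 2 and compound 1 sit within the scatter of each other in this assay, the only step being a 1.0-fold higher number from compound 1 to compound 2 (0.02 log units; within the scatter). Compound 3 `CCC(C)(C)Cc1c[nH]c(CCc2ccc(-n3ccnn3)cc2)n1` carries 1H-1,2,3-triazol-1-yl in place of 1H-pyrazol-1-yl on an aromatic carbon. Within the data shown here, the one step that bears on this, the swap of 6-methylpyridin-2-yl for 1H-pyrazol-1-yl, left the number unchanged within the scatter, so no step beyond the scatter is expected here either. Compound 3 is therefore estimated at 120 nM (range 50 nM to 300 nM), an expected step of a 1.1-fold higher number from compound 2 to compound 3 (0.05 log units; within the scatter).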

Compound 3, half-maximal effective concentration: 93 nM
The estimate for compound 3 lay 1.3-fold (0.11 log units) above the measured number; low and high end bracket the measured number.
By their numbers in this assay, from the lowest: compounds 3, 1 and 2 (each within the scatter of the next).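

In this assay, 1H-1,2,3-triazol-1-yl in place of 1H-pyrazol-1-yl on the aromatic carbon para to a large group gives a 1.1-fold lower number from compound 2 to compound 3 (0.06 log units; within the scatter) and so adds a second azole to the level set, despite the extra ring nitrogen. The same holds against 6-methylpyridin-2-yl, with a 1.1-fold lower number from compound 1 to compound 3 (0.04 log units; within the scatter) across the wider swap. All three aromatic groups at this position therefore read alike.

Open, going by these compounds, is whether a non-aromatic group here, such as an amine or a carboxylic acid, would hold the number. No supporting measurement explains why these groups read alike.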